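Methylating a Ring Hydroxy in Benzothiazole Hydrazones

A few compounds are considered here, and "the series" means these few. Any claim that something is new, unique, unknown or untested is made for them only; others in the source may bear on it.

Measured compounds:
compound 1, `COc1cc(/C=N/N(C)c2nc3ccccc3s2)cc(OC)c1O`, 107%
compound 2, `COc1cc(/C=N/N(C)c2nc3ccccc3s2)cc(OC)c1OC`, 7%
compound 3, `Oc1ccc(/C=N/Nc2nc3ccccc3s2)cc1O`, 33%

In a functional assay on cells (Mus musculus) for cytotoxicity, read by MTT assay, with a stated time of 24 h, tested at 1 uM (on this read-out higher numbers stand for a stronger effect at the one concentration tested and lower numbers for a weaker effect), compound 1 gives 107%, while compound 2 gives 7%. Compound 2 differs from compound 1 only by methyl in place of hydrogen on an oxygen on an aromatic ring, and this change produced a number 100 percentage points lower from compound 1 to compound 2 (beyond the scatter). Compound 3 gives 33% in this assay, placing it between the other two; how the core of compound 3 differs from that of compound 1 is not broken down here.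

Compound 4, `COc1cc(/C=N/Nc2nc3ccccc3s2)ccc1O`, has not yet been measured. It differs from compound 3 by methyl in place of hydrogen on an oxygen on an aromatic ring, the same change that turned compound 1 into compound 2. Since that earlier step was large and downward, a downward step is expected here too, though compound 3 starts from a lower value, so the room to fall is smaller. The expected step from compound 3 to compound 4 in this assay is a number 23 percentage points lower from compound 3 to compound 4 (beyond the scatter), resting on a number 100 percentage points lower from compound 1 to compound 2 (beyond the scatter). Compound 4 is therefore estimated to give about 10%, most likely between 0% and 35%.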

Compound 4, a percentage reported as activity, at one concentration (the size of the read-out at that concentration, not a potency): 44%
Compound 4: middle estimate off by 34 percentage points, on the low side; measured number outside the range, above it.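

Replacing hydrogen with methyl on the ring oxygen, which turns hydroxy into methoxy, gave a number 11 percentage points higher from compound 3 to compound 4 (beyond the scatter) in this assay, whereas the same change gave a number 100 percentage points lower from compound 1 to compound 2 (beyond the scatter) on the other core. The two steps point in opposite directions and differ clearly in size: the same change on two cores in this assay, a number 100 percentage points lower (beyond the scatter) from compound 1 to compound 2 and a number 11 percentage points higher (beyond the scatter) from compound 3 to compound 4, 111 percentage points apart, beyond the scatter of two such steps. So in this series the effect of the change cannot simply be carried from one core to another, although two pairs show neither why the outcomes differ nor which core's behaviour would be the more common.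

The compounds shown leave open how a third core would respond to the same change, since the two known steps offer no single trend to extend. They also leave open whether a different group on that oxygen, such as an ethyl group or a longer chain, or an amine in place of the hydroxy, would follow either step in this cell read-out.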